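Formyl to methoxy on the shared core of compound 3

The compounds below may be only part of what the source reports. "The series", "measured", "known", "first", "only" and "open" are said of these compounds alone.

Measured in an assay on HEK-293T cells for inhibition of diacylglycerol lipase-alpha (Homo sapiens), read by colorimetric assay; on this read-out lower numbers stand for stronger inhibition and higher numbers for weaker inhibition:
compound 1 `O=C(CCCCCCc1ccccc1)c1nc(C(=O)C(F)(F)F)co1`, 123 nM
compound 2 `CC(C)(C)C(=O)c1coc(C(=O)CCCCCCc2ccccc2)n1`, 479 nM
compound 3 `O=Cc1coc(C(=O)CCCCCCc2ccccc2)n1`, 1510 nM

Compound 3 stands highest of the three numbers: a 3.2-fold higher number from compound 2 to compound 3 (0.50 log units; beyond the scatter) and a 12-fold higher number from compound 1 to compound 3 (1.09 log units; beyond the scatter) both lie beyond the scatter, so it is the weakest of the set. Compound 4 `COc1coc(C(=O)CCCCCCc2ccccc2)n1` differs from compound 3 by methoxy in place of formyl on an aromatic carbon. For the measured compounds named here, no measured step covers this change directly: the steps so far, a 3.9-fold higher number from compound 1 to compound 2 (0.59 log units; beyond the scatter), a 12-fold higher number from compound 1 to compound 3 (1.09 log units; beyond the scatter) and a 3.2-fold higher number from compound 2 to compound 3 (0.50 log units; beyond the scatter), only exchange the group on a carbonyl carbon, while compound 4 removes that carbonyl altogether. Across those three the number rises as trifluoromethyl gives way to tert-butyl and then to hydrogen, and compound 4 departs still further from compound 1. A further weakening beyond the scatter is therefore expected, a 3.3-fold higher number from compound 3 to compound 4 (0.52 log units; beyond the scatter), with wide uncertainty. Compound 4 is estimated at 5000 nM, range 1500 nM to 20000 nM.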

Compound 4, half-maximal inhibitory concentration: > 10000 nM
Compound 4 gave a limit, no number; the forecaster's own chance of this, stated with the estimate: 25%; at least 2.0-fold (0.30 log units) between middle value and limit.
By their numbers in this assay, from the lowest: compound 1; then compound 2; then compound 3. At a limit, above all of these: compound 4.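

Compound 4 gives only a limit, > 10000 nM, not a number. Formyl and methoxy count the same in heavy atoms and hydrogen-bond acceptors, yet the change gives an at least 6.6-fold higher number from compound 3 to compound 4 (0.82 log units; beyond the scatter). The wider comparisons, an at least 20-fold higher number from compound 2 to compound 4 (1.31 log units; beyond the scatter) and an at least 81-fold higher number from compound 1 to compound 4 (1.91 log units; beyond the scatter), show that whereas exchanges on the carbonyl left measurable values in compound 1, compound 2 and compound 3, removing that carbonyl from this aromatic carbon takes inhibition out of the measured range.

Going by these compounds, how far compound 4 lies past its limit remains open. Also open, on these data alone, is whether any carbonyl at this carbon suffices, as an amide or a carboxylic acid there would test.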